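From nitro to cyano: what compound 3 may show

A few compounds are considered here, and "the series" means these few. Any claim that something is new, unique, unknown or untested is made for them only; others in the source may bear on it.

Compound 1 (`COc1cc2oc(-c3cccc(NC(=O)c4ccc(F)cc4)c3)cc(=O)c2c(OC)c1OC`): 14700 nM 
Compound 2 (`COc1cc2oc(-c3cccc(NC(=O)c4ccc([N+](=O)[O-])cc4)c3)cc(=O)c2c(OC)c1OC`): 20100 nM 

In a functional assay on MCF7 cells (Homo sapiens) for inhibition, read by MTT assay (on this read-out higher numbers stand for weaker inhibition of growth and lower numbers for stronger inhibition of growth), compound 2 has a single measured neighbour, compound 1, and the two numbers lie within the scatter of each other. Compound 3 (`COc1cc2oc(-c3cccc(NC(=O)c4ccc(C#N)cc4)c3)cc(=O)c2c(OC)c1OC`) keeps everything in compound 2 except one group, with cyano in place of nitro on an aromatic carbon, para to a large group (cyano in place of nitro on an aromatic carbon). Within the data shown here, the only measured step at this place is a 1.4-fold higher number from compound 1 to compound 2 (0.14 log units; within the scatter) for nitro in place of fluoro. That one step is thin evidence, but it gives no reason to expect a step beyond the scatter in this assay for the new group. The expected step is a 1.2-fold lower number from compound 2 to compound 3 (0.07 log units; within the scatter) as an estimate. Compound 3 is estimated at 17000 nM with an expected range from 8000 nM to 38000 nM in this read-out.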

Compound 3, concentration for 50% growth inhibition: 12700 nM
Estimate against measurement, compound 3: 1.3-fold (0.13 log units) above; the range from low to high includes it.
By their numbers in this assay, from the lowest: compounds 3, 1 and 2 (each within the scatter of the next).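

In this assay, cyano at this place gives a 1.6-fold lower number from compound 2 to compound 3 (0.20 log units; within the scatter) against nitro, and a 1.2-fold lower number from compound 1 to compound 3 (0.06 log units; within the scatter) against fluoro. With three groups now read on this aromatic carbon, para to a large group, all three pairs among compounds 1, 2 and 3 lie within the scatter of each other, so the position has not yet separated fluoro, nitro and cyano in this read-out, where one step alone could not show that. No measurement shown here accounts for these numbers.

As far as these compounds go, it remains open whether a different kind of group at this place, such as an amine, a carboxylic acid or a longer chain, would give a step beyond the scatter. From the compounds shown here alone, it is also open whether fluoro, nitro and cyano would stay this close on another carbon of the same ring.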